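A few compounds are considered here, and "the series" means these few. Any claim that something is new, unique, unknown or untested is made for them only; others in the source may bear on it.

Measured compounds:
- compound 1 `CC(=O)OC[C@H]1O[C@@H](n2cc(CN3C(=O)/C(=C/c4ccc(C)cc4)c4ccccc43)nn2)[C@H](OC(C)=O)[C@@H](OC(C)=O)[C@@H]1OC(C)=O`: 16000 nM
- compound 2 `CC(=O)OC[C@H]1O[C@@H](n2cc(CN3C(=O)/C(=C\c4ccc(C)cc4)c4ccccc43)nn2)[C@H](OC(C)=O)[C@@H](OC(C)=O)[C@@H]1OC(C)=O`: 16500 nM
- compound 3 `CC(=O)OC[C@H]1O[C@@H](n2cc(CN3C(=O)/C(=C/c4ccc5ccccc5c4)c4ccccc43)nn2)[C@H](OC(C)=O)[C@@H](OC(C)=O)[C@@H]1OC(C)=O`: 30900 nM

In a functional assay on A549 cells (Homo sapiens) for cytotoxicity, read by sulforhodamine B assay, with a stated time of 48 h (a lower number here means a stronger inhibitor, a higher number a weaker inhibitor), compound 2 holds the second highest of the three numbers, nearest compound 1 and furthest from compound 3, all within the scatter. The step of a 1.0-fold higher number from compound 1 to compound 2 (0.01 log units; within the scatter) is small, and (the fact that compounds 1 and 2 differ only in the configuration as drawn). The step of a 1.9-fold higher number from compound 1 to compound 3 (0.29 log units; within the scatter) touched the same place that compound 4 `CCC/C=C1\C(=O)N(Cc2cn([C@@H]3O[C@H](COC(C)=O)[C@@H](OC(C)=O)[C@H](OC(C)=O)[C@H]3OC(C)=O)nn2)c2ccccc21` now alters: propyl in place of 4-methylphenyl on a double-bonded chain carbon bound to a double-bonded ring carbon. Within the data shown here, that measured step swapped one aromatic group for another, whereas compound 4 puts propyl where the aromatic group stood, a larger departure that no measured pair covers. She therefore expects no step beyond the scatter, or at most a modest rise in the number, and the step from compound 2 to compound 4 is estimated as a 1.5-fold higher number from compound 2 to compound 4 (0.18 log units; within the scatter). Compound 4 is estimated at 25000 nM, within 9000 nM to 80000 nM.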

Compound 4, half-maximal inhibitory concentration: 40400 nM
Compound 4: the middle estimate sits 1.6-fold (0.21 log units) below what was measured; measured number inside the range.
By their numbers in this assay, from the lowest: compounds 1, 2, 3 and 4 (each within the scatter of the next, the first and the last beyond it).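

In this assay, among these compounds, the change to propyl gives a 2.4-fold higher number from compound 2 to compound 4 (0.39 log units; beyond the scatter), the first step at this position to pass beyond the scatter, though it remains modest. The earlier swap at this place, naphthalen-2-yl in place of 4-methylphenyl, exchanged one aromatic group for another and stayed within the scatter, whereas propyl carries no ring. Nothing in the information available gives a cause for this step.

The compounds shown leave open how a longer chain, or a chain ending in an amine or a carboxylic acid, would compare with propyl at this place.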